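Benzyl ether variation and cytotoxicity in the shared core series

The compounds below may be only part of what the source reports. "The series", "measured", "known", "first", "only" and "open" are said of these compounds alone.

Measured so far in an ADME assay on Huh-5-2 cells (Homo sapiens) for cytotoxicity, read by WST assay, with a stated time of 3 days; on this read-out higher numbers stand for lower toxicity in this test and lower numbers for higher toxicity in this test:
compound 1 `O=c1c(OCc2ccccc2Br)c(-c2ccccc2)oc2cc(O)cc(O)c12`: 12000 nM
compound 2 `N#Cc1cccc(COc2c(-c3ccccc3)oc3cc(O)cc(O)c3c2=O)c1`: 21000 nM

Within the data shown here, compound 2 holds the higher of the two numbers, but the only measured step, a 1.8-fold higher number from compound 1 to compound 2 (0.24 log units; within the scatter), lies within the scatter, so no order between compound 1 and compound 2 can be read from these two values. Compound 3 `O=c1c(OCc2ccc(Br)cc2)c(-c2ccccc2)oc2cc(O)cc(O)c12` has not yet been measured. It differs from compound 2 in one place: 4-bromophenyl in place of 3-cyanophenyl on a saturated chain carbon bound to an oxygen on an aromatic ring. Among the measured compounds shown here, the one measured step that bears on this change is the earlier exchange of the same benzyl substituent, a 1.8-fold higher number from compound 1 to compound 2 (0.24 log units; within the scatter), which did not move the number beyond the scatter. With a bromine returning to the benzyl group, now as 4-bromophenyl, and no other change, a step beyond the scatter is not expected in this assay; the expected step is a 1.4-fold lower number from compound 2 to compound 3 (0.15 log units; within the scatter). For compound 3 the estimate in this assay is 15000 nM, with a range from 6000 nM to 40000 nM, taking compound 1 with 12000 nM and compound 2 with 21000 nM as the two anchors.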

Compound 3, half-maximal cytotoxic concentration: 2000 nM
Estimate against measurement, compound 3: 7.5-fold (0.88 log units) above; measured number below the stated range.
By their numbers in this assay, from the lowest: compound 3; then compounds 1 and 2 (each within the scatter of the next).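

In this assay, the group on the saturated chain carbon bound to an oxygen on an aromatic ring proves able to move the number well beyond the scatter: 4-bromophenyl in place of 3-cyanophenyl gives an 11-fold lower number from compound 2 to compound 3 (1.02 log units; beyond the scatter), which the exchange between the first two compounds gave no sign of. Bromine alone does not account for the low number, since 4-bromophenyl in place of 2-bromophenyl, with the shared core unchanged, gives a 6.0-fold lower number from compound 1 to compound 3 (0.78 log units; beyond the scatter), so the two bromophenyl isomers are separated in this test and compound 3 stands as the most toxic of the three, with its steps to both others beyond the scatter. No measurement at hand accounts for this difference between the isomers.

The compounds shown do not tell whether the low number goes with the bromine or with the place it occupies on the ring, a question that 3-bromophenyl and 4-cyanophenyl at this position would bear on directly. Also open, as far as these compounds go, is how this number responds to an amine or a carboxylic acid on the benzyl ring, or to a longer chain in place of the single carbon bound to the oxygen.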